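Cytotoxicity notes: fluoro on the benzamide of compound 3

The compounds below may be only part of what the source reports. "The series", "measured", "known", "first", "only" and "open" are said of these compounds alone.

Measured compounds in a functional assay on RXF 393 cells (Homo sapiens) for cytotoxicity; a higher number here means that more compound is tolerated, a lower number that less compound is tolerated:
compound 1 `COc1cccc(-c2nn(-c3ccccc3)cc2-c2ccnc(NCCNC(=O)Nc3cccc(C(F)(F)F)c3)c2)c1` gives 25000 nM
compound 2 `COc1cccc(-c2nn(-c3ccccc3)cc2-c2ccnc(NCCCNC(=O)Nc3ccc(Cl)c(Cl)c3)c2)c1` gives 23000 nM
compound 3 `O=C(NCCCNc1cc(-c2cn(-c3ccccc3)nc2-c2cccc(O)c2)ccn1)c1ccccc1` gives 100000 nM

Compound 3 stands at the highest number of the three in this assay; its nearest neighbour is compound 1 and its furthest is compound 2, and both of those gaps lie beyond the usual scatter. Compound 3 is therefore the best tolerated of the measured set.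

Compound 4 `O=C(NCCCNc1cc(-c2cn(-c3ccccc3)nc2-c2cccc(O)c2)ccn1)c1ccc(F)cc1` is the next member. It differs from compound 3 by fluoro in place of hydrogen on an aromatic carbon, sitting para to a large group on the benzoyl ring, so the benzamido end becomes ((4-fluorophenyl)carbonyl)amino.

Among the measured compounds shown here, no pair differing in one place has been measured, so nothing in this set shows what a single fluoro on that ring does. The expected step is none beyond the scatter: compound 4 is expected to give 80000 nM (range 30000 nM to 200000 nM), a step of a 1.3-fold lower number from compound 3 to compound 4 (0.10 log units; within the scatter) that is estimated to stay within the usual scatter.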

Compound 4, concentration lethal to 50% of the cells: 5990 nM
Beside the measured number, compound 4's estimate is 13-fold (1.13 log units) above it; the measured number lies below the stated range.
By their numbers in this assay, from the lowest: compound 4; then compounds 2 and 1 (each within the scatter of the next); then compound 3.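

In this assay, the benzoyl ring turns out to be a sensitive part of the molecule: with fluoro in place of hydrogen para to a large group, the series shows a 17-fold lower number from compound 3 to compound 4 (1.22 log units; beyond the scatter). Among the compounds shown here, this is the only single-place change that can be read so far, and adding one heavy atom at this position is enough to produce a large step rather than a change lost in the scatter. No measurement available here accounts for the size of this step.

From the compounds shown here alone, whether this step is specific to fluoro or would also follow from another group at the same place remains open; chloro, methoxy, nitrile or an amine there would help separate the two. Also open, going by these compounds, is whether a longer chain in the linker would keep the same fluoro step.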